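The source may hold more compounds than are shown below. What is called first, only, known or untested is meant among the compounds shown, and "the series" means these compounds.

Compound 1 `CC1(C)[N+]([O-])=c2ccc(COc3ccc(C=O)cc3)cc2=[N+]1[O-]`: 65 uM
Compound 2 `NC(=S)N/N=C/c1cccc(OCc2ccc3no[n+]([O-])c3c2)c1`: "nd(insoluble)" (no result reported)
Compound 3 `CC1(C)[N+]([O-])=c2ccc(COc3ccc(/C=N/NC(N)=S)cc3)cc2=[N+]1[O-]`: "nd(insoluble)" (no result reported)

Among the measured compounds shown here, in an ADME assay on cells (Erythrocyte, Homo sapiens), read by spectrophotometry and hemolysis, with a stated time of 24 h (a higher number here means a weaker inhibitor, a lower number a stronger inhibitor), compound 1 gives 65 uM, the only number so far. Compound 2 gives "nd(insoluble)" (no result reported). Compound 3 gives "nd(insoluble)" (no result reported), so it has no number to be ranked by. Compound 4 `C=CCNC(=S)N/N=C/c1ccc(OCc2ccc3c(c2)=[N+]([O-])C(C)(C)[N+]=3[O-])cc1` is compound 3 with one change: allyl in place of hydrogen on an amide-type nitrogen. For the measured compounds named here, no measured pair shows this change, so the expected step in this assay is none beyond the scatter, in neither direction. Going by the values given here, the only anchor is compound 1 at 65 uM, and that anchor is weak. The estimate for compound 4 is 60 uM, with an expected range from 20 uM to 180 uM.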

Compound 4, concentration for 50% inhibition: > 100 uM
Compound 4: only a limit was reported; the forecaster's own chance of this, stated with the estimate: 25%; middle value at least 1.6-fold (0.22 log units) away from the limit.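

With allyl in place of hydrogen on an amide-type nitrogen, compound 3, which has no reported result, becomes compound 4, which has a reading in this assay: compound 4 gives > 100 uM, a limit of the assay and not a number. Exchanging the whole group on the aromatic carbon gives an at least 1.5-fold higher number from compound 1 to compound 4 (0.18 log units; that floor lies within the scatter), so this pair shows no firm difference. The reading rests on that limit: the limit of > 100 uM in this assay, at which 1 of the 4 values shown sits.

Going by these compounds, how far compound 4 lies past its limit remains open. So does what a methyl group, a butyl chain or a carboxylic acid-bearing chain on that nitrogen would give in this assay.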